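Side-group swaps on one aromatic carbon, flat so far

This account rests on a few compounds, and the source may have more. Where it says the series, first, only, none or still open, it means among the compounds named here.

compound 1 `Cc1nn(C)c2nc(NNC(=O)Nc3cc(Cl)nc(Cl)c3)cc(C3CC3)c12` gives 67700 nM
compound 2 `CCCc1cc(NNC(=O)Nc2cc(Cl)nc(Cl)c2)nc2c1c(C)nn2C` gives 72200 nM
compound 3 `COc1ccc(-c2cc(NNC(=O)Nc3cc(Cl)nc(Cl)c3)nc3c2c(C)nn3C)cc1` gives 82300 nM

All three values come from a functional assay on HCT-116 cells (Homo sapiens) for cytotoxicity, read by MTT assay, with a stated time of 48 h, in the presence of a further agent that is not named here; on this read-out lower numbers stand for an effect already at smaller amounts and higher numbers for an effect only at larger amounts of compound. Compound 3, at 82300 nM, stands level with compound 1 and compound 2, and the scatter separates none of the three.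

Compound 4 `Cc1nn(C)c2nc(NNC(=O)Nc3cc(Cl)nc(Cl)c3)cc(-c3ccco3)c12` is still to be measured. It differs from compound 3 in one place: furan-2-yl in place of 4-methoxyphenyl on an aromatic carbon. Furan-2-yl replaces 4-methoxyphenyl on an aromatic carbon, opposite the ring nitrogen.

All three measured steps change the group at this same place: a 1.1-fold higher number from compound 1 to compound 2 (0.03 log units; within the scatter), a 1.2-fold higher number from compound 1 to compound 3 (0.08 log units; within the scatter) and a 1.1-fold higher number from compound 2 to compound 3 (0.06 log units; within the scatter). Each lies within the scatter, so cyclopropyl, propyl and 4-methoxyphenyl cannot be told apart on these numbers. No five-membered aromatic ring has yet been measured here, which leaves the new group untested and the range wide. No step beyond the scatter is therefore expected in this assay, in either direction. The estimated change is a 1.1-fold lower number from compound 3 to compound 4 (0.06 log units; within the scatter). The expected value for compound 4 is 72000 nM, with an estimated range from 40000 nM to 115000 nM.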

Compound 4, half-maximal effective concentration: 69200 nM
Beside the measured number, compound 4's estimate is 1.0-fold (0.02 log units) above it; the measured number falls inside the stated range.
By their numbers in this assay, from the lowest: compounds 1, 4, 2 and 3 (each within the scatter of the next).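

In this assay the first five-membered aromatic ring at this place, furan-2-yl, gives steps that all lie within the scatter: a 1.2-fold lower number from compound 3 to compound 4 (0.08 log units; within the scatter) and a 1.0-fold lower number from compound 2 to compound 4 (0.02 log units; within the scatter) and a 1.0-fold higher number from compound 1 to compound 4 (0.01 log units; within the scatter). The flat picture therefore now extends to a five-membered aromatic ring with one hetero atom, and to a group with fewer heavy atoms than 4-methoxyphenyl but the same count of hydrogen-bond acceptors, so cyclopropyl, propyl, 4-methoxyphenyl and furan-2-yl cannot be told apart at this aromatic carbon opposite the ring nitrogen. No measurement is available that would account for this flat result.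

Still open, from the compounds shown here alone, is whether an amine, a carboxylic acid or a chain longer than propyl at this place would give a step beyond the scatter. Going by these compounds, all four compounds are identical outside this one place, so the effect of any change elsewhere on the shared core also remains open.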